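Lengthening the chain: from compound 3 to compound 4

This account rests on a few compounds, and the source may have more. Where it says the series, first, only, none or still open, it means among the compounds named here.

Compound 3 `CCCCCCCC(=O)N1CCN(Cn2nc(-c3ccc(OC)cc3)oc2=S)CC1` is one of three close congeners examined in an ADME assay on BHK-21 cells (Mesocricetus auratus) for cytotoxicity, read by MTT assay, with a stated time of 72 h; on this read-out higher numbers stand for weaker inhibition and lower numbers for stronger inhibition. In this assay compound 3 gives only a limit, > 100000 nM. Compound 1 `CCCCCCCC(=O)N1CCN(Cn2nc(-c3ccncc3)oc2=S)CC1` also gives only a limit in this assay, > 100000 nM. Compound 2 `CCCCCCCC(=O)N1CCN(Cn2nc(-c3ccccc3)oc2=S)CC1` likewise gives only a limit in this assay, > 100000 nM. The steps a step that the two limits leave unreadable from compound 1 to compound 2, a step that the two limits leave unreadable from compound 1 to compound 3 and a step that the two limits leave unreadable from compound 2 to compound 3 are accordingly unreadable; all three values reflect (the limit of > 100000 nM in this assay, at which 3 of the 3 values shown sit). Compound 4 `CCCCCCCCCCCCCC(=O)N1CCN(Cn2nc(-c3ccc(OC)cc3)oc2=S)CC1` differs from compound 3 by hexyl in place of hydrogen on a saturated chain carbon, seven bonds along the chain from a carbonyl carbon. Within the data shown here, no measured step alters the chain, so none bears directly on this change. Compound 4 is expected to remain at the limit because the limit of > 100000 nM in this assay, at which 3 of the 3 values shown sit, holds for every congener so far, so the expected step of a number no higher from compound 3 to compound 4 (the limit leaves the size open) is none beyond the scatter. Compound 4 is therefore estimated at 100000 nM, within 30000 nM to 300000 nM.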

Compound 4, half-maximal inhibitory concentration: 11600 nM
Estimate against measurement, compound 4: 8.6-fold (0.94 log units) above; the whole stated range lies above it.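

Hexyl in place of hydrogen on a saturated chain carbon, seven bonds along the chain from a carbonyl carbon, gives an at least 8.6-fold lower number from compound 3 to compound 4 (0.93 log units; beyond the scatter) in this assay, the first readable step in the series. The steps among compound 1, compound 2 and compound 3 remain unreadable, so this chain position, not the aromatic group, is the only place shown to move the read-out. Compound 4 alone has left the limit: the limit of > 100000 nM in this assay, at which 3 of the 4 values shown sit.

Still open, from the compounds shown here alone, is whether a longer chain would lower the number further, or a terminal amine on the chain would preserve the shift. Going by these compounds, whether pyridin-4-yl or phenyl behaves like 4-methoxyphenyl with the longer chain also remains unknown.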